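The compounds below may be only part of what the source reports. "The series", "measured", "known", "first", "only" and "open" are said of these compounds alone.

Measured compounds:
compound 1 `COc1ccc(-c2nnc(SCCn3c([N+](=O)[O-])cnc3C)o2)cc1` — 5800 nM
compound 2 `Cc1ncc([N+](=O)[O-])n1CCSc1nnc(-c2ccccc2N)o1` — 4500 nM

In a functional assay on HepG2 cells (Homo sapiens) for cytotoxicity, read by MTT assay, with a stated time of 48 h (on this read-out lower numbers stand for stronger inhibition and higher numbers for weaker inhibition), compound 1 gives 5800 nM, the highest of the two numbers, and compound 2 is the nearest at 4500 nM. Going by the values given here, the only measured step, a 1.3-fold lower number from compound 1 to compound 2 (0.11 log units; within the scatter), swaps the 4-methoxyphenyl for another aryl group and stays within the scatter.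

Compound 3 `Cc1ncc([N+](=O)[O-])n1CCSc1nnc(-c2ccc(Cl)cc2)o1` differs from compound 1 by chloro in place of methoxy on an aromatic carbon. Among the compounds with values here, that one step bears on it, since it also alters the 4-methoxyphenyl of compound 1, but it introduces a different group and its size was within the scatter; no measured compound carries chloro. The expected step of a 1.2-fold lower number from compound 1 to compound 3 (0.06 log units; within the scatter) is therefore none beyond the scatter in this assay. Compound 3 is estimated at 5000 nM, with a range from 2200 nM to 11000 nM.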

Compound 3, half-maximal inhibitory concentration: 7800 nM
Beside the measured number, compound 3's estimate is 1.6-fold (0.19 log units) below it; the range from low to high includes it.
By their numbers in this assay, from the lowest: compounds 2, 1 and 3 (each within the scatter of the next).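

In this assay, chloro in place of methoxy on this aromatic carbon, para to a large group, gives a 1.3-fold higher number from compound 1 to compound 3 (0.13 log units; within the scatter), so a second substituent at this place leaves the number inside the scatter. Going by these compounds alone, this change removes the hydrogen-bond acceptor counted on methoxy and one heavy atom, with no step that can be told from the scatter. The other comparison, a 1.7-fold higher number from compound 2 to compound 3 (0.24 log units; within the scatter), is also within the scatter, so the 4-methoxyphenyl, 2-aminophenyl and 4-chlorophenyl compounds cannot be told apart here. No evidence is available that would explain these numbers.

Going by these compounds, whether a carboxylic acid, a nitrile or a longer alkoxy chain on this aromatic carbon would give a step beyond the scatter remains open. So does the effect of any change elsewhere on the shared core, since all three compounds differ only in the aryl group.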